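This account rests on a few compounds, and the source may have more. Where it says the series, first, only, none or still open, it means among the compounds named here.

Of the compounds shown here, three that share one core have been measured, and a fourth awaits its number. Compound 1 `COCc1cc(CN2CCCC2)c(O)c2ncccc12` is tested in a functional assay on MES-SA cells (Homo sapiens) for inhibition, with a stated time of 72 h, in the presence of a further agent that is not named here (on this read-out higher numbers stand for weaker inhibition and lower numbers for stronger inhibition), where compound 1 gives 10500 nM. Compound 2 `CCOCc1cc(CN2CCCC2)c(O)c2ncccc12` differs from compound 1 by methyl in place of hydrogen on a saturated chain carbon bound to an oxygen on a saturated carbon, and in this assay compound 2 gives 8710 nM; that change made a 1.2-fold lower number from compound 1 to compound 2 (0.08 log units; within the scatter). Compound 3 `COCc1cc(CN2CCC(C)CC2)c(O)c2ncccc12` differs from compound 1 by 4-methylpiperidin-1-yl in place of pyrrolidin-1-yl on a saturated chain carbon bound to an aromatic carbon, and in this assay compound 3 gives 6460 nM. Compound 4 `CCOCc1cc(CN2CCC(C)CC2)c(O)c2ncccc12` differs from compound 3 by methyl in place of hydrogen on a saturated chain carbon bound to an oxygen on a saturated carbon, the same change as from compound 1 to compound 2, at the same place, though on a core that carries the other ring. Because the earlier change made a 1.2-fold lower number from compound 1 to compound 2 (0.08 log units; within the scatter), the expected step from compound 3 to compound 4 is a 1.2-fold lower number from compound 3 to compound 4 (0.08 log units; within the scatter), equally small. Compound 4 is thus estimated at 5400 nM in this assay.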

Compound 4, half-maximal inhibitory concentration: 4470 nM
Compound 4: the middle estimate sits 1.2-fold (0.08 log units) above what was measured, and the stated range covers the measured number.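

Setting methyl in place of hydrogen on a saturated chain carbon bound to an oxygen on a saturated carbon, which turns methoxymethyl into ethoxymethyl, gives a 1.4-fold lower number from compound 3 to compound 4 (0.16 log units; within the scatter) in this assay, and the step reads alike on both cores: the same change on two cores in this assay, a 1.2-fold lower number (0.08 log units; within the scatter) from compound 1 to compound 2 and a 1.4-fold lower number (0.16 log units; within the scatter) from compound 3 to compound 4, 1.2-fold (0.08 log units) apart, within the scatter of two such steps. Putting 4-methylpiperidin-1-yl in place of pyrrolidin-1-yl gives a 1.9-fold lower number from compound 2 to compound 4 (0.29 log units; within the scatter), and this step also reads alike on both cores: the same change on two cores in this assay, a 1.6-fold lower number (0.21 log units; within the scatter) from compound 1 to compound 3 and a 1.9-fold lower number (0.29 log units; within the scatter) from compound 2 to compound 4, 1.2-fold (0.08 log units) apart, within the scatter of two such steps. Within the data shown here, all of these steps lie within the scatter, so the agreement shows only that neither change behaves visibly differently on the other core, not that either change truly alters inhibition.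

The compounds shown leave open whether a longer chain, such as propoxymethyl in place of ethoxymethyl, would give a step beyond the scatter. The same question stands for another amine, such as morpholin-4-yl in place of pyrrolidin-1-yl.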